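A few compounds are considered here, and "the series" means these few. Any claim that something is new, unique, unknown or untested is made for them only; others in the source may bear on it.

Among the compounds with values here, in a functional assay on MIA PaCa-2 cells (Homo sapiens) for inhibition, read by MTT assay, with a stated time of 3 days (a higher number here means a weaker inhibitor, a lower number a stronger inhibitor), compound 1 `CCOC(=O)[C@@H]1CCCN(S(=O)(=O)c2ccc(S(=O)(=O)N3CCOCC3)cc2)C1` gives 4100 nM as the only number so far. Compound 2 `CCOC(=O)[C@@H]1CCCN(C(=O)c2ccc(S(=O)(=O)N(CC)CC)cc2)C1` reads > 3000 nM and that entry is a limit of the assay, not a number. Within the data shown here, compound 1 therefore stands alone on the scale, with no measured step between compounds to calibrate against. Compound 3 `CCOC(=O)[C@@H]1CCCN(S(=O)(=O)c2ccc(S(=O)(=O)N(CC)C(C)C)cc2)C1` keeps the core of compound 1 and differs in one place, ethyl(isopropyl)amino in place of morpholin-4-yl on a sulfonyl sulfur in all, with ethyl(isopropyl)amino in place of morpholin-4-yl on a sulfonyl sulfur. With only compound 1 at 4100 nM as an anchor, no step beyond the usual scatter is expected in this assay and any lean would be slight, towards a stronger inhibitor. The expected step of a 1.6-fold lower number from compound 1 to compound 3 (0.21 log units; within the scatter) is an estimate and stays within that scatter. Compound 3 is estimated at 2500 nM with 800 nM to 8000 nM as the expected range.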

Compound 3, half-maximal inhibitory concentration: 1200 nM
Beside the measured number, compound 3's estimate is 2.1-fold (0.32 log units) above it, and the stated range covers the measured number.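

In this assay, within the data shown here, the group on the sulfonyl sulfur gives the first step that can be read, and it is beyond the usual scatter: a 3.4-fold lower number from compound 1 to compound 3 (0.53 log units; beyond the scatter), with ethyl(isopropyl)amino in place of morpholin-4-yl. The ring of morpholin-4-yl and its hydrogen-bond acceptor are therefore not needed at this place for a stronger inhibitor, at an unchanged count of heavy atoms in the group. Nothing measured here accounts for this step.

Among these compounds, the single step does not separate loss of the ring from loss of its oxygen, and piperidin-1-yl on the same sulfonyl sulfur would keep the ring without that oxygen. How far the open chains can be varied also remains unresolved, as does whether a carboxylic acid in place of the ethyl ester would keep the inhibition.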